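The source may hold more compounds than are shown below. What is called first, only, known or untested is meant among the compounds shown, and "the series" means these compounds.

In an ADME assay on MDCK cells (Canis lupus familiaris) for cytotoxicity, read by MTT assay, with a stated time of 48 h (on this read-out higher numbers stand for lower toxicity in this test and lower numbers for higher toxicity in this test), compound 1 `COC(=O)[C@@H](NC(=O)CSc1nc(-c2ccccc2)cc(-c2ccc(C)cc2)c1C#N)C(C)C` gives 210000 nM as a measured number. Compound 2 `COC(=O)CC[C@H](NC(=O)CSc1nc(-c2ccccc2)cc(-c2ccc(C)cc2)c1C#N)C(=O)OC` gives > 250000 nM and this is a limit, not a number. Compound 3 `Cc1ccc(-c2cc(-c3ccccc3)nc(SCC(=O)N[C@H](C(=O)N[C@@H](CC(=O)O)C(=O)O)C(C)C)c2C#N)cc1` gives > 250000 nM and this too is a limit. Compound 2 therefore stands at the limit of > 250000 nM in this assay, at which 2 of the 3 values shown sit, and has no exact number of its own.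

In compound 4 `Cc1ccc(-c2cc(-c3ccccc3)nc(SCC(N)=O)c2C#N)cc1` hydrogen stands in place of 1,3-bis(methoxycarbonyl)propyl on an amide-type nitrogen (hydrogen in place of 1,3-bis(methoxycarbonyl)propyl on an amide-type nitrogen). The shared core stays as it is, so the whole change lies in this one group.

Two measured steps offer guidance, though neither removes that group entirely. Putting 2-(methoxycarbonyl)ethyl in place of isopropyl gives an at least 1.1-fold higher number from compound 1 to compound 2 (0.07 log units; that floor lies within the scatter) and putting (1,2-dicarboxyethyl)amino in place of methoxy gives an at least 1.1-fold higher number from compound 1 to compound 3 (0.07 log units; that floor lies within the scatter). Neither shows a change beyond the scatter, so no large change is expected here. Compound 1 at 210000 nM is the only exact anchor, which points to an expected number close to that one.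

The estimated change is an at least 1.3-fold lower number from compound 2 to compound 4 (0.14 log units; that floor lies within the scatter) and it is expected to be small, with a somewhat lower number if any change appears. Compound 4 is expected at 180000 nM (estimated range 70000 nM to 300000 nM) in this assay when measured.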

Compound 4, half-maximal cytotoxic concentration: > 250000 nM
Compound 4: no number, only a limit (the forecaster's own chance of this, stated with the estimate: 45%); at least 1.3-fold (0.14 log units) between middle value and limit.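

In this assay compound 4 gives > 250000 nM, which is a limit and not a number. Replacing the whole 1-(methoxycarbonyl)-2-methylpropyl group of compound 1 with hydrogen on the amide-type nitrogen gives an at least 1.1-fold higher number from compound 1 to compound 4 (0.07 log units; that floor lies within the scatter), and because that floor lies within the scatter, this step does not establish a real difference, even though the earlier compounds had only shown swaps of one part of a substituent for another and never the bare amide. The step between compound 2 and compound 4 cannot be read, but a value at the limit now appears with either 1,3-bis(methoxycarbonyl)propyl or plain hydrogen on this nitrogen, so no substituent there is needed to reach it: the limit of > 250000 nM in this assay, at which 3 of the 4 values shown sit.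

The compounds shown leave open how far past the limit compound 2, compound 3 and compound 4 lie, so these three cannot be ordered against one another. Also open, going by these compounds, is whether a benzyl group or an aminoethyl chain on the same amide-type nitrogen would give an exact number in this assay.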